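A few compounds are considered here, and "the series" means these few. Any claim that something is new, unique, unknown or untested is made for them only; others in the source may bear on it.

Measured so far:
compound 1, `CC(C)=CCn1c(CN2CCN(C(=O)C3CC3)CC2)nc2ccccc21`, 74.3%
compound 2, `Cc1cccc(Cn2c(CN3CCN(C(=O)C4CCCC4)CC3)nc3ccccc32)c1`, 67.5%
compound 3, `Cc1cccc(Cn2c(OC3CCN(C(=O)C4CC4)CC3)nc3ccccc32)c1`, 80.6%

All three were tested in an assay on isolated protein for inhibition of aldehyde dehydrogenase 1A1 (Homo sapiens), read by spectrophotometry, tested at 10 uM; a lower number here means less inhibition, a higher number more inhibition at the concentration tested (going by the name of the read-out). Compound 2 holds the lowest of the three numbers. Its nearest neighbour is compound 1, whose value lies higher by an amount within the usual scatter, so the two cannot be told apart; compound 3 lies higher by an amount beyond the scatter, so compound 3 shows more inhibition than compound 2.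

Compound 4, `CCC(=O)N1CCN(Cc2nc3ccccc3n2Cc2cccc(C)c2)CC1`, has not yet been tested. It differs from compound 2 in one place: ethyl in place of cyclopentyl on a carbonyl carbon. Cut one bond further out, the change reads cyclopentylcarbonyl to propanoyl, on a carbonyl carbon whose other neighbour is an amide-type nitrogen in a ring.

For the measured compounds named here, no measured pair shows this kind of change, so its effect in this assay is unknown. Compound 1 carries a smaller ring at the same carbonyl and gives 74.3%, which sits within the scatter of compound 2. On that basis the step from compound 2 to compound 4 is expected to be small, a number 2.5 percentage points lower from compound 2 to compound 4 (within the scatter), not clearly beyond the scatter in either direction. Compound 4 is therefore estimated to give 65%, expected to fall between 48% and 80%.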

Compound 4, a percentage reported as inhibition, at one concentration (the size of the read-out at that concentration, not a potency): 85.1%
The estimate for compound 4 lay 20.1 percentage points below the measured number, outside the stated range (above it).
By their numbers in this assay, from the lowest: compounds 2, 1, 3 and 4 (each within the scatter of the next, the first and the last beyond it).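

Replacing cyclopentyl with ethyl on the carbonyl carbon gives a clear change in this assay: the result is a number 17.6 percentage points higher from compound 2 to compound 4 (beyond the scatter), and this is the only step shown for a change in just one place. It shows that this position is sensitive to the group it carries, and that a small open chain without a ring is compatible with strong inhibition at the concentration tested, at least on the background shared by compound 2 and compound 4. The compounds shown contain no measurement that explains why the number moves.

One pair cannot separate the loss of the ring from the drop in heavy atoms, and cyclopropyl on this carbonyl appears only in compounds that also differ elsewhere, so it cannot settle the question. Still open, going by these compounds, is how this background would respond to methyl, to a longer chain such as butyl, or to an amine in place of ethyl, and whether any of these would keep the higher number seen with ethyl.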